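Sulfur for selenium on two cores: cytotoxicity notes

This account rests on a few compounds, and the source may have more. Where it says the series, first, only, none or still open, it means among the compounds named here.

Measured so far:
- Compound 1 `CS/C(=N\C(=O)c1cc(-c2ccccc2)nc2ccccc12)NC(=O)c1cc(-c2ccccc2)nc2ccccc12`: in a functional assay on HepG2 cells (Homo sapiens) for cytotoxicity, read by MTT assay, with a stated time of 72 h (on this read-out higher numbers stand for lower toxicity in this test and lower numbers for higher toxicity in this test), compound 1 gives > 100000 nM, which is a limit of the assay and not a number.
- Compound 2 `C[Se]/C(=N\C(=O)c1cc(-c2ccccc2)nc2ccccc12)NC(=O)c1cc(-c2ccccc2)nc2ccccc12`: in this assay compound 2 gives 65400 nM.
- Compound 3 `C[Se]/C(=N\C(=O)c1cnc2ccccc2c1)NC(=O)c1cnc2ccccc2c1`: in this assay compound 3 gives 87800 nM.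

Among the measured compounds shown here, the one counted change is a group of 2 heavy atoms (1 carbon, 1 sulfur; no ring) in place of a group of 2 heavy atoms (1 carbon, 1 selenium; no ring), on a carbon with a double bond to nitrogen. It made an at least 1.5-fold higher number from compound 2 to compound 1 (0.18 log units; that floor lies within the scatter). The difference between the core of compound 2 and the core of compound 3 is not broken down here; their two values sit within the scatter of each other.

Compound 4 `CS/C(=N\C(=O)c1cnc2ccccc2c1)NC(=O)c1cnc2ccccc2c1` carries the same change on the core of compound 3: a group of 2 heavy atoms (1 carbon, 1 sulfur; no ring) in place of a group of 2 heavy atoms (1 carbon, 1 selenium; no ring), on a carbon with a double bond to nitrogen. The place lines match word for word, so this is the same change. The step expected from it is a 1.4-fold higher number from compound 3 to compound 4 (0.14 log units; within the scatter), resting on the measured step from compound 2 to compound 1, which itself is only a floor because of the limit of > 100000 nM in this assay, at which 1 of the 3 values shown sits. Compound 4 is therefore expected to give about 120000 nM, between 70000 nM and 250000 nM, with a fair chance that the assay again reports only a limit.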

Compound 4, concentration lethal to 50% of the cells: > 100000 nM
Compound 4 gave a limit, no number; the forecaster's own chance of this, stated with the estimate: 60%; the middle value lies beyond the limit too.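

In this assay compound 4 gives > 100000 nM, which is a limit of the assay and not a number. Methylsulfanyl in place of the selenium-bearing group gives an at least 1.1-fold higher number from compound 3 to compound 4 (0.05 log units; that floor lies within the scatter), and set beside the earlier core the change reads as follows: the same change on two cores in this assay, an at least 1.5-fold higher number (0.18 log units; that floor lies within the scatter) from compound 2 to compound 1 and an at least 1.1-fold higher number (0.05 log units; that floor lies within the scatter) from compound 3 to compound 4; the limit leaves it open whether they differ Compound 1 and compound 4 both stop at the limit, so the series shows only floors for this change, each within the scatter, and it does not show the size of the step on either core or whether the step carries over unchanged: the limit of > 100000 nM in this assay, at which 2 of the 4 values shown sit.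

The compounds shown leave open how the swap of sulfur for selenium would read on a core whose sulfur compound gives a number and not a limit. They also leave open what a longer chain on the sulfur or the selenium, such as ethylsulfanyl, or an amine in place of methylsulfanyl on the carbon with a double bond to nitrogen, would give in this assay.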